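Oxime ether chain shortening in a quinone series

The source may report more compounds than this note shows. Statements on the series, on what has been measured and on what is new or still open speak of the compounds shown alone.

Of the compounds shown here, two carry numbers so far. Compound 1 `CCCCCC/C(=N\OCCC)c1cc(OC)c2c(c1OC)C(=O)C=CC2=O` gives 0.166 ug/mL in a functional assay on L1210 cells (Mus musculus) for antiproliferative activity; on this read-out lower numbers stand for an effect already at smaller amounts and higher numbers for an effect only at larger amounts of compound. Compound 2 `COc1cc(/C=N/OCc2ccccc2)c(OC)c2c1C(=O)C=CC2=O`, with a benzyl oxime ether in place of the side chain, gives 0.264 ug/mL in this assay. The two numbers lie within the scatter of each other, so compound 1 stands alongside compound 2 rather than apart from it; neither can be set ahead of the other.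

Compound 3 `CCCCCC/C(=N\OC)c1cc(OC)c2c(c1OC)C(=O)C=CC2=O` has not yet been measured. It differs from compound 1 in one place: hydrogen in place of ethyl on a saturated chain carbon bound to an oxygen, so the propoxy on the oxime becomes a methoxy. Among the measured compounds shown here, no step between two measured compounds of this kind is available, so the size of the step must be judged from the change alone. With the shared core untouched and only the chain on the oxime oxygen shortened, the step from compound 1 is expected to be small, if anything toward a somewhat higher number, and most likely within the scatter. The expected step is a 1.3-fold higher number from compound 1 to compound 3 (0.12 log units; within the scatter). On that basis compound 3 is estimated at 0.22 ug/mL in this assay, with a range from 0.08 ug/mL to 0.6 ug/mL.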

Compound 3, concentration for half-maximal effect: 0.192 ug/mL
The estimate for compound 3 lay 1.1-fold (0.06 log units) above the measured number, and the stated range covers the measured number.
By their numbers in this assay, from the lowest: compounds 1, 3 and 2 (each within the scatter of the next).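

In this assay, among the compounds shown here, the step of a 1.2-fold higher number from compound 1 to compound 3 (0.06 log units; within the scatter) is the first reading for a single change: hydrogen in place of ethyl on a saturated chain carbon bound to an oxygen. Propoxy and methoxy at this place are therefore not told apart by this read-out, and the loss of 2 carbon atoms, with no ring, no hydrogen-bond donor or acceptor and no net charge involved, leaves the number within the scatter. Compound 1 and compound 2 differ in more than one place and could not speak to this position alone, and no measurement available here bears on why the two chains read alike.

On these data alone, only propoxy and methoxy are compared at this place, so whether a longer chain such as octyloxy, or a chain ending in an amine or a carboxylic acid, would stay within the scatter of compound 1 remains open. The step also rests on a single pair in one cell assay, so it cannot yet be carried over to other side chains on the shared core.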